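A few compounds are considered here, and "the series" means these few. Any claim that something is new, unique, unknown or untested is made for them only; others in the source may bear on it.

Working notes on the series. In a functional assay on HepG2 cells (Homo sapiens) for antiproliferative activity, read by MTT assay (on this read-out lower numbers stand for stronger inhibition and higher numbers for weaker inhibition), compound 1 (`O=C1N=C(N2CCC[C@H]2C(=O)Nc2ccc3ncnc(Nc4cccc(Cl)c4)c3c2)S/C1=C/c1ccccc1Cl`) gives 28100 nM. For the measured compounds named here, compound 2 (`O=C1N=C(N2CCC[C@H]2C(=O)Nc2ccc3ncnc(Nc4cccc(Cl)c4)c3c2)S/C1=C/c1cccs1`) gives 4120 nM, the lower of the two numbers so far. Compound 3 (`COc1ccccc1/C=C1/SC(N2CCC[C@H]2C(=O)Nc2ccc3ncnc(Nc4cccc(Cl)c4)c3c2)=NC1=O`) has not been measured in this assay. The change is 2-methoxyphenyl in place of thiophen-2-yl on a double-bonded chain carbon bound to a double-bonded ring carbon, with 2-methoxyphenyl in place of thiophen-2-yl on a double-bonded chain carbon bound to a double-bonded ring carbon.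

A single measured step bears on this: a 6.8-fold lower number from compound 1 to compound 2 (0.83 log units; beyond the scatter), a modest change made at the same place, with thiophen-2-yl in place of 2-chlorophenyl. Compound 3 has a six-membered aromatic ring of carbon only there, as does compound 1 at 28100 nM, so a step to a higher number, beyond the scatter and of similar or somewhat smaller size, is expected. The expected step is a 3.4-fold higher number from compound 2 to compound 3 (0.53 log units; beyond the scatter). For compound 3 the estimate is 14000 nM, with an expected range of 5000 nM to 35000 nM.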

Compound 3, half-maximal inhibitory concentration: 22100 nM
For compound 3 the middle estimate is 1.6-fold (0.20 log units) below the measured one, within the range that was stated.
By their numbers in this assay, from the lowest: compound 2; then compounds 3 and 1 (each within the scatter of the next).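

Replacing thiophen-2-yl with 2-methoxyphenyl gives the second step of this kind at this place (a 5.4-fold higher number from compound 2 to compound 3 (0.73 log units; beyond the scatter)), now with a substituent other than chloro on the six-membered aromatic ring of carbon only. Methoxy in place of chloro on that ring leaves the numbers within the scatter of each other (a 1.3-fold lower number from compound 1 to compound 3 (0.10 log units; within the scatter)), so among these three compounds the thiophen-2-yl compound stands apart from both substituted rings, with no compound going against this. Nothing measured here accounts for the gap.

An unsubstituted phenyl at this place would show whether the gap follows the ring itself or the chloro and methoxy groups on it. As far as these compounds go, how a ring bearing an amine or a carboxylic acid would behave at this place also stays open.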